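The source may report more compounds than this note shows. Statements on the series, on what has been measured and on what is new or still open speak of the compounds shown alone.

Of the compounds shown here, three have been tested in a functional assay on the whole organism (Tail, strain ICR) with Mus musculus as the target, in the tail flick test, with a stated time of 120 min, at a dose of 25 umol/kg by the oral route; on this read-out lower numbers stand for a weaker effect and higher numbers for a stronger effect at the one dose given. Compound 1, `N=C(N)NCCC[C@H](NC(=O)CN(c1ncnc2c1ncn2C1CCCCO1)C1CC1)C(=O)OCc1ccccc1`, gives 38.2%. Compound 2, `CSCC[C@H](NC(=O)CN(c1nc(Cl)nc2[nH]cnc12)C1CC1)C(=O)OCc1ccccc1`, gives 31.6%. Compound 3, `C[C@@H](O)[C@H](NC(=O)CN(c1nc(Cl)nc2[nH]cnc12)C1CC1)C(=O)O`, gives 37.6%, a number that sits between those of the other two, with the gap to compound 1 and the gap to compound 2 both within the usual scatter, so the three compounds cannot be told apart on this read-out.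

Compound 4, `NC(=O)CC[C@H](NC(=O)CN(c1nc(Cl)nc2[nH]cnc12)C1CC1)C(=O)O`, shares the core of compound 3 and differs from it in one place: 2-carbamoylethyl in place of 1-hydroxyethyl on a saturated chain carbon bound to an amide-type nitrogen and a carbonyl carbon. Going by the values given here, no measured pair shows what such a change does here, so no step beyond the scatter is expected. The expected step of a number 1.6 percentage points lower from compound 3 to compound 4 (within the scatter) stays within the scatter. Compound 4 is estimated to give 36%, with a range from 24% to 48%.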

Compound 4, a percentage reported as activity, at one dose (the size of the read-out at that dose, not a potency): 17.8%
Compound 4: middle estimate off by 18.2 percentage points, on the high side, outside the stated range (below it).
By their numbers in this assay, from the lowest: compound 4; then compounds 2, 3 and 1 (each within the scatter of the next).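

In this assay, the saturated chain carbon bound to an amide-type nitrogen and a carbonyl carbon proves sensitive to its substituent: 2-carbamoylethyl in place of 1-hydroxyethyl gives a number 19.8 percentage points lower from compound 3 to compound 4 (beyond the scatter), the only step shown that lies beyond the scatter. So a change at this one place can weaken the effect at the dose given. Nothing measured here explains this step.

Going by these compounds, it remains open whether the carbamoyl end or the chain carrying it matters. A 2-carboxyethyl or 2-aminoethyl group at this place on the same core would help to separate the two.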